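A few compounds are considered here, and "the series" means these few. Any claim that something is new, unique, unknown or untested is made for them only; others in the source may bear on it.

Measured so far:
- compound 1 `N#Cc1ccc(S(=O)(=O)N2C[C@H](S(=O)(=O)c3ccc(Cl)cc3)[C@](O)(CO)C2)c(Cl)c1`: 100%
- compound 2 `N#Cc1ccc(S(=O)(=O)N2C[C@H](S(=O)(=O)c3ccc(Cl)cc3)[C@](O)(CO)C2)cn1`: 62%

In an ADME assay on the whole organism (Rattus norvegicus, strain Sprague-Dawley) for pharmacokinetics, read by LC-MS, at a dose of 2 mg/kg by the oral route (on this read-out lower numbers stand for lower oral bioavailability and higher numbers for higher oral bioavailability), compound 2 gives 62%, the lower of the two numbers, and compound 1 gives 100%. Compound 3 `N#Cc1ccc(S(=O)(=O)N2C[C@H](S(=O)(=O)c3ccc(Cl)cc3)[C@](O)(CO)C2)c(C(F)(F)F)n1` has trifluoromethyl in place of hydrogen on an aromatic carbon, next to the ring nitrogen, ortho to a large group and meta to a cyano group: trifluoromethyl in place of hydrogen on an aromatic carbon.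

Going by the values given here, only one measured step bears on this change. It is a number 38 percentage points lower from compound 1 to compound 2 (beyond the scatter), which is large and beyond the scatter, and it concerns the same group on the sulfonyl sulfur. With 6-cyanopyridin-3-yl unsubstituted at the new carbon, a single step gives only weak guidance on the new substituent. A moderate rise in this assay is expected, with the estimated step being a number 13 percentage points higher from compound 2 to compound 3 (beyond the scatter). For compound 3 the expected value is 75%, within an estimated range of 48% to 98%.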

Compound 3, oral bioavailability: 8%
Estimate against measurement, compound 3: 67 percentage points above; the whole stated range lies above it.
By their numbers in this assay, from the lowest: compound 3; then compound 2; then compound 1.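

In this assay, trifluoromethyl in place of hydrogen on the aromatic carbon next to the ring nitrogen gives a number 54 percentage points lower from compound 2 to compound 3 (beyond the scatter), a large step from one substituent on the 6-cyanopyridin-3-yl group. Going by these compounds alone, this is the first reading at this carbon, which is unsubstituted in compound 2, and it runs in the same direction as the earlier change on the sulfonyl sulfur, a number 38 percentage points lower from compound 1 to compound 2 (beyond the scatter). No measurement at hand gives a reason for the drop.

From the compounds shown here alone, whether the step belongs to trifluoromethyl itself or would come with any group on this carbon remains open. A methyl, a methoxy or an amine at the same place would help separate these two readings.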